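Replacing a cyanobenzyl arm with cyclopropylmethyl

A few compounds are considered here, and "the series" means these few. Any claim that something is new, unique, unknown or untested is made for them only; others in the source may bear on it.

Three compounds sharing one core have been measured in a functional assay on RAW264.7 cells (Mus musculus) for inhibition, read by Griess assay, with stated times of 2 h and 24 h; a lower number here means a stronger inhibitor, a higher number a weaker inhibitor:
compound 1 `COc1ccc([C@@H]2CC(=O)c3c(O)cc(OCc4cn(Cc5ccccc5Cl)nn4)cc3O2)cc1O` gives 6140 nM;
compound 2 `COc1ccc([C@@H]2CC(=O)c3c(O)cc(OCc4cn(Cc5ccccc5F)nn4)cc3O2)cc1O` gives 7320 nM;
compound 3 `COc1ccc([C@@H]2CC(=O)c3c(O)cc(OCc4cn(Cc5ccccc5C#N)nn4)cc3O2)cc1O` gives 14600 nM.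

Compound 3 stands at the highest number of the three, so it is the weakest inhibitor among them. Its distance from compound 1 is a 2.4-fold higher number from compound 1 to compound 3 (0.38 log units; beyond the scatter), while against compound 2 the gap is a 2.0-fold higher number from compound 2 to compound 3 (0.30 log units; within the scatter). Between compound 1 and compound 2 the change is a 1.2-fold higher number from compound 1 to compound 2 (0.08 log units; within the scatter).

Compound 4 `COc1ccc([C@@H]2CC(=O)c3c(O)cc(OCc4cn(CC5CC5)nn4)cc3O2)cc1O` differs from compound 3 in this way: cyclopropyl in place of 2-cyanophenyl on a saturated chain carbon bound to an aromatic nitrogen. Among the measured compounds shown here, none of the measured steps describes such a change; they only swapped one substituent for another on the same aromatic ring, and those swaps moved the number modestly at most. With the whole ring gone, the measured steps give no direct guide, so only a loose expectation is possible. Compound 4 is expected to land near the measured compounds, with the step of a 1.6-fold lower number from compound 3 to compound 4 (0.21 log units; within the scatter), giving an estimate of 9000 nM within a range from 3000 nM to 30000 nM.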

Compound 4, half-maximal inhibitory concentration: 11900 nM
The estimate for compound 4 lay 1.3-fold (0.12 log units) below the measured number; low and high end bracket the measured number.
By their numbers in this assay, from the lowest: compounds 1, 2, 4 and 3 (each within the scatter of the next, the first and the last beyond it).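

Among the compounds shown here, at the saturated chain carbon bound to an aromatic nitrogen, the earlier compounds changed only a substituent on the aromatic ring, whereas compound 4 removes that ring from the arm altogether. In this assay, cyclopropyl replaces each of the three aromatic arms without a step beyond the scatter (a 1.2-fold lower number from compound 3 to compound 4 (0.09 log units; within the scatter); a 1.6-fold higher number from compound 2 to compound 4 (0.21 log units; within the scatter); a 1.9-fold higher number from compound 1 to compound 4 (0.29 log units; within the scatter)), so among these compounds an aromatic ring in this arm is not needed for a number in this range, and an arm of 3 heavy atoms sits level with ones of 8 or so. Nothing shown here explains this result.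

From the compounds shown here alone, whether a longer chain, an amine or a carboxylic acid in place of cyclopropyl would move the number beyond the scatter stays open. So does whether a stronger inhibitor can be reached by changing this arm at all.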